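The source may report more compounds than this note shows. Statements on the series, on what has been measured and on what is new or still open speak of the compounds shown alone.

Compound 1 `CCC(CC)c1ccc2c(NCCCNCc3cc(F)ccc3OC)ccnc2c1` gives 7860 nM in an ADME assay on HepG2 cells (Homo sapiens) for cytotoxicity, read by luminescence, CellTiter-Glo and ATP content, with a stated time of 72 h (a higher number here means that more compound is needed for the effect, a lower number that less compound is needed), the highest of the three numbers recorded. Compound 2 `CCC(CC)c1ccc2c(NCCCNCc3ccco3)ccnc2c1` gives 6760 nM in this assay, and compound 3 `CCC(CC)c1ccc2c(NCCCNCc3cccc(OC)c3O)ccnc2c1` gives 410 nM. The step of a 1.2-fold lower number from compound 1 to compound 2 (0.07 log units; within the scatter) and the step of a 19-fold lower number from compound 1 to compound 3 (1.28 log units; beyond the scatter) both alter the group on the saturated chain carbon bound to the amine nitrogen, and the same holds for a 16-fold lower number from compound 2 to compound 3 (1.22 log units; beyond the scatter). Compound 4 `COc1ccc(F)cc1CNCCCNc1ccnc2cc(CCc3ccccc3)ccc12` differs from compound 1 at a different place: phenethyl in place of pentan-3-yl on an aromatic carbon. Among the measured compounds shown here, no measured step touches that position, so the pairs at hand give no direction for it, and no step beyond the scatter is expected. The expected step is a 1.1-fold lower number from compound 1 to compound 4 (0.05 log units; within the scatter). Compound 4 is therefore estimated at 7000 nM, with a range from 2500 nM to 20000 nM.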

Compound 4, half-maximal effective concentration: 4240 nM
For compound 4 the middle estimate is 1.7-fold (0.22 log units) above the measured one; the range from low to high includes it.
By their numbers in this assay, from the lowest: compound 3; then compounds 4, 2 and 1 (each within the scatter of the next).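

Among the compounds shown here, the first measured step at this aromatic carbon, phenethyl in place of pentan-3-yl, gives a 1.9-fold lower number from compound 1 to compound 4 (0.27 log units; within the scatter) in this assay. At this position, then, a group of 8 heavy atoms with one six-membered aromatic ring replaces one of 5 heavy atoms with no ring, and the change stays within the scatter. The compounds shown leave open whether an amine or a carboxylic acid at this carbon would also stay within the scatter, and whether phenethyl would do so alongside the 2-hydroxy-3-methoxyphenyl group of compound 3. Nothing available accounts for this result.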